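Compound 3: 3,4-dimethylphenyl to 4-bromophenyl

The source may hold more compounds than are shown below. What is called first, only, known or untested is meant among the compounds shown, and "the series" means these compounds.

Values in a functional assay on MCF-A cells (Homo sapiens) for cytotoxicity; a higher number here means a weaker inhibitor of growth, a lower number a stronger inhibitor of growth:
compound 1 `COc1ccc(C2=C(c3ccc(SC)cc3)CC3CCCN3C2=O)cc1OC(=O)CNC(=O)OC(C)(C)C` gives 6000 nM
compound 2 `COc1ccc(C2=C(c3ccc(SC)cc3)CC3CCCN3C2=O)cc1OC(=O)C1CCCN1C(=O)OC(C)(C)C` gives 4000 nM
compound 3 `CSc1ccc(C2=C(c3ccc(C)c(C)c3)C(=O)N3CCCC3C2)cc1` gives 800 nM

Compound 3 stands lowest of the three at 800 nM and lies beyond the scatter from both others. The next structure, compound 4 `CSc1ccc(C2=C(c3ccc(Br)cc3)C(=O)N3CCCC3C2)cc1`, has 4-bromophenyl in place of 3,4-dimethylphenyl on a double-bonded ring carbon. For the measured compounds named here, the only measured step, a 1.5-fold lower number from compound 1 to compound 2 (0.18 log units; within the scatter), concerns a group on a carbonyl carbon at another place and gives no guide to this change. No step beyond the scatter is therefore expected in this assay, and no direction can be assigned. The expected result is no change at the digits printed from compound 3 to compound 4 (within the scatter) as an estimate. For compound 4 the estimated value is 800 nM (expected range 250 nM to 2500 nM).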

Compound 4, concentration for 50% growth inhibition: 8000 nM
Compound 4: middle estimate off by 10-fold (1.00 log units), on the low side, and the stated range ends below it.
By their numbers in this assay, from the lowest: compound 3; then compounds 2, 1 and 4 (each within the scatter of the next).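

In this assay, 4-bromophenyl in place of 3,4-dimethylphenyl on the double-bonded ring carbon gives a 10-fold higher number from compound 3 to compound 4 (1.00 log units; beyond the scatter) and shows that this position responds to a change of its aryl group. The step occurs although both groups count no hydrogen-bond donors or acceptors and carry no net charge. Nothing available explains the step.

The compounds shown leave open whether the loss follows from adding bromine or from removing the methyl groups. They also leave open how 4-methylphenyl, or a phenyl bearing an amine or a carboxylic acid, would behave here.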